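The source may report more compounds than this note shows. Statements on the series, on what has been measured and on what is new or still open speak of the compounds shown alone.

Compound 1 `O=C(/C=C/c1ccoc1)c1cc(O)c(O)c([N+](=O)[O-])c1` carries a furan-3-yl on a double-bonded chain carbon bound to a double-bonded chain carbon. For the measured compounds named here, in an assay for inhibition of Catechol O-methyltransferase (Rattus norvegicus), read by fluorescence and spectrophotometry (a higher number here means a weaker inhibitor, a lower number a stronger inhibitor), compound 1 gives 290 nM, the higher of the two numbers measured so far; compound 2 `CC(=O)N1N=C(c2cc(O)c(O)c([N+](=O)[O-])c2)CC1c1ccoc1` gives 180 nM in this assay, and the two values lie within the scatter of each other, so neither can be called the stronger inhibitor. Compound 3 `Cn1cc(/C=C/C(=O)c2cc(O)c(O)c([N+](=O)[O-])c2)cn1` differs from compound 1 by 1-methyl-1H-pyrazol-4-yl in place of furan-3-yl on a double-bonded chain carbon bound to a double-bonded chain carbon. Going by the values given here, no measured pair shows the effect of such a change, and the two numbers in hand give no guide to its direction. The step from compound 1 to compound 3 is therefore expected to be a 1.0-fold higher number from compound 1 to compound 3 (0.01 log units; within the scatter), a change estimated to stay within the scatter. Compound 3 is expected to give 300 nM in this assay, with a likely range from 120 nM to 750 nM.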

Compound 3, half-maximal inhibitory concentration: 290 nM
The estimate for compound 3 lay 1.0-fold (0.01 log units) above the measured number, within the range that was stated.
By their numbers in this assay, from the lowest: compounds 2, 1 and 3 (each within the scatter of the next).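

In this assay, putting 1-methyl-1H-pyrazol-4-yl in place of furan-3-yl on a double-bonded chain carbon bound to a double-bonded chain carbon gives no change at the digits printed from compound 1 to compound 3 (within the scatter), the first single change measured at this position. The position therefore accepts a five-membered aromatic ring with 2 hetero atoms, both nitrogen and one bearing a methyl group, as well as one with a single oxygen, without a change beyond the scatter. No measurement in hand accounts for this result.

On these data alone, whether a phenyl ring, a dimethylamino group or a carboxylic acid at this place would leave the number equally unmoved remains open. As far as these compounds go, it is also open whether the same exchange of rings would hold on the core of compound 2.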